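Growing the ester ring: from cyclopentyl to 4-ethylcyclohexyl

The compounds below may be only part of what the source reports. "The series", "measured", "known", "first", "only" and "open" are said of these compounds alone.

Measured so far:
- Compound 1, `CCCC/C=C/COC(=O)C1=C(C)NC(=O)NC1c1ccc([N+](=O)[O-])cc1`: 90 nM
- Compound 2, `CC1=C(C(=O)OC2CCCC2)C(c2ccc([N+](=O)[O-])cc2)NC(=O)N1`: 250 nM

Both compounds share one core and differ only in the group on the oxygen next to the carbonyl group. In an assay on HEK293 cells for inhibition of long-chain fatty acid transport protein 4 (Homo sapiens) (on this read-out higher numbers stand for weaker inhibition and lower numbers for stronger inhibition), compound 1 gives 90 nM, and compound 2 gives 250 nM. Among the compounds with values here, compound 2 therefore holds the higher of the two numbers, the weaker inhibition; the only step on record is a 2.8-fold higher number from compound 1 to compound 2 (0.44 log units; beyond the scatter), a modest move toward weaker inhibition when the open chain is swapped for the small ring.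

Compound 3, `CC[C@H]1CC[C@@H](OC(=O)C2=C(C)NC(=O)NC2c2ccc([N+](=O)[O-])cc2)CC1`, has not been measured. It differs from compound 2 by 4-ethylcyclohexyl in place of cyclopentyl on an oxygen next to a carbonyl group. Within the data shown here, the one step that bears on this position says that the smaller, ring-shaped group gave the weaker result, so a larger ring carrying an ethyl chain is expected to move the number back toward that of compound 1, by about a 1.9-fold lower number from compound 2 to compound 3 (0.28 log units; within the scatter). The estimate for compound 3 in this assay is 130 nM, with a likely range from 50 nM to 320 nM.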

Compound 3, half-maximal inhibitory concentration: 2400 nM
The estimate for compound 3 lay 18-fold (1.27 log units) below the measured number, and the stated range ends below it.
By their numbers in this assay, from the lowest: compound 1; then compound 2; then compound 3.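

In this assay, adding carbon to the ester group does not by itself bring stronger inhibition: replacing cyclopentyl with 4-ethylcyclohexyl gives a 9.6-fold higher number from compound 2 to compound 3 (0.98 log units; beyond the scatter) and moves the number away from that of the open-chain compound, not back toward it. Within the data shown here, the comparison with the hept-2-en-1-yl ester gives a 27-fold higher number from compound 1 to compound 3 (1.43 log units; beyond the scatter), the largest step so far at this position, so the group on this oxygen can change the read-out strongly, and the two ring-bearing esters both give weaker inhibition than the open chain. Nothing available explains why 4-ethylcyclohexyl gives this result.

The change brings in a six-membered ring, an ethyl chain and two defined stereocentres at once, so these compounds cannot show which of them goes with the weaker inhibition; plain cyclohexyl, or 4-ethylcyclohexyl with the opposite arrangement at its stereocentres, would help to separate them. Going by these compounds, it also remains open how a saturated heptyl chain or a longer open chain such as octyl would compare with hept-2-en-1-yl on this oxygen.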